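The compounds below may be only part of what the source reports. "The series", "measured", "known", "first", "only" and "open" are said of these compounds alone.

Measured so far, in a functional assay on DU-145 cells (Homo sapiens) for cytotoxicity, read by MTT assay, with a stated time of 2 days, tested at 10 uM; on this read-out lower numbers stand for less inhibition and higher numbers for more inhibition at the one concentration tested (going by the name of the read-out):
compound 1, `Cc1cccc(N2CCN(CCCNc3nc(NCc4ccco4)c4ccccc4n3)CC2)c1C`, gives 91.5%
compound 2, `Clc1cccc(N2CCN(CCCNc3nc(NCc4ccco4)c4ccccc4n3)CC2)c1Cl`, gives 93.2%
compound 3, `Clc1cccc(N2CCN(CCCCNc3nc(NCc4ccco4)c4ccccc4n3)CC2)c1Cl`, gives 94.3%

All three numbers lie within the scatter of one another, so no order among them can be read. Among the measured compounds shown here, the one counted change among the measured compounds is 2,3-dimethylphenyl in place of 2,3-dichlorophenyl on an amine nitrogen in a ring, and its step in this assay, a number 1.7 percentage points lower from compound 2 to compound 1 (within the scatter), is within the scatter. How the core of compound 2 differs from the core of compound 3 is not broken down here; compound 2 gives 93.2% and compound 3 gives 94.3%, again within the scatter.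

Compound 4, `Cc1cccc(N2CCN(CCCCNc3nc(NCc4ccco4)c4ccccc4n3)CC2)c1C`, is not yet measured. It stands to compound 3 as compound 1 stands to compound 2: 2,3-dimethylphenyl in place of 2,3-dichlorophenyl on an amine nitrogen in a ring, the same change at the same place. Because the earlier step, a number 1.7 percentage points lower from compound 2 to compound 1 (within the scatter), was within the scatter, the step of a number 1.8 percentage points lower from compound 3 to compound 4 (within the scatter) is expected to be of the same small size. In this assay compound 4 is therefore expected to give about 92.5%, estimated to lie between 86% and 97%.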

Compound 4, a percentage reported as inhibition, at one concentration (the size of the read-out at that concentration, not a potency): 93.6%
For compound 4 the middle estimate is 1.1 percentage points below the measured one; low and high end bracket the measured number.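

In this assay, placing 2,3-dimethylphenyl where 2,3-dichlorophenyl stood on the core of compound 3 gives a number 0.7 percentage points lower from compound 3 to compound 4 (within the scatter), and this step agrees with the step for the same change on the other core: the same change on two cores in this assay, a number 1.7 percentage points lower (within the scatter) from compound 2 to compound 1 and a number 0.7 percentage points lower (within the scatter) from compound 3 to compound 4, 1 percentage points apart, within the scatter of two such steps Across these two pairs, the change therefore carries from one core to the other as a step too small to read, with no sign that the core alters it. This does not show that the two aryl groups are equivalent in potency: the read-out comes from one concentration, all four numbers lie high on a percentage scale, and two cores say nothing about any other core.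

The compounds shown leave open how an unsubstituted phenyl or a methoxyphenyl on the same ring nitrogen would read. They also leave open whether the change would still carry over with a longer chain in the linker, or at lower concentrations where differences among these compounds might be seen.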